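A few compounds are considered here, and "the series" means these few. Any claim that something is new, unique, unknown or untested is made for them only; others in the source may bear on it.

Among the compounds with values here, only one number exists so far for the shared core. Within the data shown here, in a physicochemical assay for lipophilicity, at pH 7.4 (on this read-out higher numbers stand for higher lipophilicity and lower numbers for lower lipophilicity), compound 1 (`Clc1ccc(C2Cc3nccn3C2)cc1`) gives 2.6 as the sole reading. Among the measured compounds shown here, compound 2 (`NC(=O)c1ccccc1C1Cc2nccn2C1`) has only the entry "not determined" (no result reported) and so holds no place on the scale, and no measured step starts from it. Compound 3 (`Clc1ccccc1C1Cc2nccn2C1`) still awaits measurement. It differs from compound 2 in one place: chloro in place of carbamoyl on an aromatic carbon, ortho to a group of 8 heavy atoms.

For the measured compounds named here, no measured pair gives the size of this step. In this assay the step is expected to run upward and to exceed the usual scatter, although this cannot be checked while compound 2 lacks a number. Going by the values given here, the only anchor is compound 1 at 2.6 on this read-out, which also carries a chloro group on an aromatic carbon, at a different place. Compound 3 is expected to lie close to that reading, with no gap clearly beyond the scatter. For compound 3 the estimate is 2.4 with 2 to 2.8 as the expected range.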

Compound 3, distribution coefficient: 2.6
For compound 3 the middle estimate is 0.20 log units below the measured one; low and high end bracket the measured number.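

No new step can be read from compound 3, since compound 2 offers no single number in this assay to set against it. The compounds shown leave open the size and direction of the change from carbamoyl to chloro on this read-out. No evidence bearing on the result is available.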